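The source may report more compounds than this note shows. Statements on the series, on what has been measured and on what is new or still open speak of the compounds shown alone.

Measured so far in an ADME assay on HEK293 cells (Homo sapiens) for cytotoxicity, read by CellTiter-Glo and resazurin assay, with a stated time of 72 h; on this read-out lower numbers stand for an effect already at smaller amounts and higher numbers for an effect only at larger amounts of compound:
compound 1 `CC(C)N(Cc1cccc(OCCCCCC(=O)O)c1)C(=O)c1ccc(-c2ccncc2)cc1`: > 26000 nM
compound 2 `CCOc1cccc(-c2ccc(C(=O)N(Cc3cccc(OCCCCCC(=O)O)c3)C(C)C)cc2)c1`: > 20800 nM
compound 3 `CC(C)N(Cc1cccc(OCCCCCC(=O)O)c1)C(=O)c1ccc(-c2ccc3c(c2)OCCO3)cc1`: > 21900 nM

In this assay compound 1 gives only a limit, > 26000 nM, not a number. Compound 2 likewise gives only a limit, > 20800 nM. Compound 3 also gives only a limit, > 21900 nM. The three measured steps, a step that the two limits leave unreadable from compound 1 to compound 2, a step that the two limits leave unreadable from compound 1 to compound 3 and a step that the two limits leave unreadable from compound 2 to compound 3, cannot be sized, since every value sits at a limit (the limit of > 20800 nM in this assay, at which 1 of the 3 values shown sits, (the limit of > 21900 nM in this assay, at which 1 of the 3 values shown sits), (the limit of > 26000 nM in this assay, at which 1 of the 3 values shown sits)). Compound 4 `CCOC(=O)CCCCCOc1cccc(CN(C(=O)c2ccc(-c3ccncc3)cc2)C(C)C)c1` differs from compound 1 by ethyl in place of hydrogen on an oxygen next to a carbonyl group. For the measured compounds named here, no measured step touches that part of the molecule, so the change a step that the limit leaves unreadable from compound 1 to compound 4 is expected to stay within the scatter. Compound 4 is expected to give 30000 nM, in the range 10000 nM to 100000 nM, most likely once more only a limit.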

Compound 4, half-maximal effective concentration: > 26000 nM
Compound 4 ended at the assay's limit (the forecaster's own chance of this, stated with the estimate: 85%); the middle value does not contradict the limit.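

Compound 1 and compound 4 each give only a limit, so the change from carboxy to ethoxycarbonyl cannot be sized. The compounds shown leave open what concentration, if any, would produce a half-maximal effect in this assay.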